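The source may hold more compounds than are shown below. What is called first, only, known or untested is meant among the compounds shown, and "the series" means these compounds.

Measured so far:
compound 1 `CCOC(=O)CCCCCOc1cccc(CNC(C)C)c1` — > 26000 nM
compound 2 `CCOC(=O)CCCCCOc1ccc(CNC(C)C)cc1` — > 26000 nM
compound 3 `CCCNCc1cccc(OCCCCCC(=O)OCC)c1` — > 26000 nM

The read-out for all three is an ADME assay on Raji cells (Homo sapiens) for cytotoxicity, read by CellTiter-Glo and resazurin assay, with a stated time of 72 h; on this read-out lower numbers stand for an effect already at smaller amounts and higher numbers for an effect only at larger amounts of compound. In this assay compound 1 gives > 26000 nM, which is a limit of the assay and not a number. Compound 2 likewise gives > 26000 nM in this assay, again a limit. Compound 3 gives > 26000 nM, also a limit.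

Compound 3 arises from compound 1 by one change, (propyl in place of isopropyl on an amine nitrogen). Because both values are limits, this gives a step that the two limits leave unreadable from compound 1 to compound 3. Among the compounds with values here, the only evidence on this step is the limit of > 26000 nM in this assay, at which 3 of the 3 values shown sit.

Compound 4 `CCCNCc1ccc(OCCCCCC(=O)OCC)cc1` has not yet been measured in this assay. It arises from compound 2 by propyl in place of isopropyl on an amine nitrogen, and the place of the change is described in the same words as for the pair of compound 1 and compound 3, so it is the same change made on a different core. How the core of compound 2 differs from the core of compound 1 is not broken down here.

Because compound 1, compound 2 and compound 3 all sit at the limit of > 26000 nM in this assay, at which 3 of the 3 values shown sit, the step from compound 2 to compound 4 is expected to be a number no higher from compound 2 to compound 4 (the limit leaves the size open), matching the earlier one. Compound 4 is therefore expected to give 26000 nM in this assay, between 13000 nM and 60000 nM, most probably reported again as a limit.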

Compound 4, half-maximal effective concentration: > 26000 nM
Compound 4: only a limit was reported; the forecaster's own chance of this, stated with the estimate: 85%; the middle value lies on the limit itself.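

In this assay compound 4 gives > 26000 nM, which is a limit of the assay and not a number. Compound 2 gives > 26000 nM, also a limit, and no new step can be read between compound 2 and compound 4. The compounds shown leave open whether propyl in place of isopropyl on an amine nitrogen alters the read-out on either core, since all the evidence is one limit: the limit of > 26000 nM in this assay, at which 4 of the 4 values shown sit.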